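Amide-linked series: benzoyl to acetyl at the core amine

A few compounds are considered here, and "the series" means these few. Any claim that something is new, unique, unknown or untested is made for them only; others in the source may bear on it.

Of the compounds shown here, three of the shared core have been measured in an assay for inhibition of MAP kinase-interacting serine/threonine-protein kinase 1 (Homo sapiens), with stated times of 10 min and 60 min; a higher number here means a weaker inhibitor, a lower number a stronger inhibitor. Compound 1 `CN1CCN(C(=O)c2ccc(-c3cn4c(-c5ccc(C(=O)NO)cc5)cnc4cn3)cc2)CC1` gives 60 nM, compound 3 `NC(=O)c1ccc(-c2cn3c(-c4ccc(O)cc4)cnc3cn2)cc1` gives 310 nM, and compound 2 `O=C(Nc1cn2c(-c3ccc(O)cc3)cnc2cn1)c1ccccc1` gives 3350 nM, the highest number of the three; compound 3 stands nearest to it, with a gap beyond the scatter, and compound 1 stands furthest from it, again beyond the scatter. Compound 4 `CC(=O)Nc1cn2c(-c3ccc(O)cc3)cnc2cn1` differs from compound 2 by methyl in place of phenyl on a carbonyl carbon. For the measured compounds named here, no measured pair shows this change, so its size can only be expected, not read off. For compound 4 in this assay a modest rise, somewhat beyond the scatter, is expected, a 1.8-fold higher number from compound 2 to compound 4 (0.25 log units; within the scatter). Compound 4 is estimated at 6000 nM, within 2000 nM to 20000 nM.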

Compound 4, half-maximal inhibitory concentration: 789 nM
Compound 4: middle estimate off by 7.6-fold (0.88 log units), on the high side; the whole stated range lies above it.
By their numbers in this assay, from the lowest: compound 1; then compound 3; then compound 4; then compound 2.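

Replacing the benzoyl with acetyl at this amide gives the first step read at this position in this assay: a 4.2-fold lower number from compound 2 to compound 4 (0.63 log units; beyond the scatter). The phenyl on the carbonyl carbon is therefore not required for inhibition, and the smaller methyl is the better of the two groups compared here. No available evidence explains this step.

A single step does not establish a trend with group size at this carbonyl carbon. Going by these compounds, how an ethyl group, a longer chain carrying an amine or a carboxylic acid would compare with methyl remains open.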